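Alpha-substituent variation on the fluoro-acid head group

The source may report more compounds than this note shows. Statements on the series, on what has been measured and on what is new or still open speak of the compounds shown alone.

Measured so far:
compound 1 `COc1ccc(F)c([C@H]2CC[C@H](COc3cccc([C@H](C4CC4)[C@@H](F)C(=O)O)c3)CC2)c1`, 28 nM in a functional assay on HEK293 cells for agonist activity at Free fatty acid receptor 1 (Rattus norvegicus), read by FLIPR and calcium flux; a higher number here means that more compound is needed for the effect, a lower number that less compound is needed
compound 2 `COc1ccc(F)c([C@H]2CC[C@H](COc3cccc([C@H](C4CC4)[C@@](C)(F)C(=O)O)c3)CC2)c1`, 0.34 nM in this assay

Compound 2 stands lowest of the two numbers, with compound 1 the nearest at an 82-fold lower number from compound 1 to compound 2 (1.92 log units; beyond the scatter). Compound 3 `COc1ccc(F)c([C@H]2CC[C@H](COc3cccc([C@H](C4CC4)C(C)(C)C(=O)O)c3)CC2)c1` carries the change (1-carboxy-1-methylethyl in place of 1-carboxy-1-fluoroethyl on a saturated chain carbon bound to an aromatic carbon and a saturated ring carbon). Within the data shown here, no measured step covers this change; the only step in hand, an 82-fold lower number from compound 1 to compound 2 (1.92 log units; beyond the scatter), concerns adding a methyl while keeping the fluorine, so it does not fix the size or direction here. Compound 3 is therefore expected near compound 2, with a modest rise allowed, a 4.4-fold higher number from compound 2 to compound 3 (0.64 log units; beyond the scatter), giving an estimate of 1.5 nM with a range of 0.3 nM to 10 nM.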

Compound 3, half-maximal effective concentration: 0.31 nM
The estimate for compound 3 lay 4.8-fold (0.68 log units) above the measured number, and the stated range covers the measured number.
By their numbers in this assay, from the lowest: compounds 3 and 2 (each within the scatter of the next); then compound 1.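

In this assay the swap to 1-carboxy-1-methylethyl gives a 1.1-fold lower number from compound 2 to compound 3 (0.04 log units; within the scatter) and so leaves the number within the scatter: at this place, fluorine is not required for a sub-nanomolar result. The second step, a 90-fold lower number from compound 1 to compound 3 (1.96 log units; beyond the scatter) against carboxy(fluoro)methyl, shows that a large drop in the number can be reached without any fluorine in the group. No measurement given here accounts for either step. As far as these compounds go, what carboxymethyl, carboxydifluoromethyl or 1-carboxycyclopropyl would give at this place stays open.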